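A 3-methoxyphenyl swap on a shared core

The compounds below may be only part of what the source reports. "The series", "measured", "known", "first", "only" and "open" are said of these compounds alone.

In a functional assay on A549 cells (Homo sapiens) for antiproliferative activity, read by MTT assay, with a stated time of 72 h (on this read-out lower numbers stand for stronger inhibition and higher numbers for weaker inhibition), compound 1 `COc1cc(-n2cnc3ccc(-c4cccc([N+](=O)[O-])c4)cc32)cc(OC)c1OC` gives 5410 nM and compound 2 `COc1cc(-n2cnc3ccc(-c4ccc(F)cc4)cc32)cc(OC)c1OC` gives 6740 nM on the same core. Compound 2 therefore stands level with compound 1 within the scatter, and no third number exists to place it against. Compound 3 `COc1cccc(-c2ccc3ncn(-c4cc(OC)c(OC)c(OC)c4)c3c2)c1` alters the same aromatic carbon, with 3-methoxyphenyl in place of 4-fluorophenyl, and 3-methoxyphenyl in place of 4-fluorophenyl on an aromatic carbon is the counted difference. For the measured compounds named here, only one measured step bears on this change, the exchange of 3-nitrophenyl for 4-fluorophenyl at that carbon. Because a 1.2-fold higher number from compound 1 to compound 2 (0.10 log units; within the scatter) is all that such an exchange has shown so far, no step beyond the scatter is expected in this assay for the new compound. The estimated size is a 1.2-fold lower number from compound 2 to compound 3 (0.09 log units; within the scatter) on this single piece of evidence. For compound 3 the expected value is 5500 nM within a range from 2000 nM to 15000 nM for now.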

Compound 3, half-maximal inhibitory concentration: 3180 nM
The estimate for compound 3 lay 1.7-fold (0.24 log units) above the measured number, within the range that was stated.
By their numbers in this assay, from the lowest: compounds 3, 1 and 2 (each within the scatter of the next, the first and the last beyond it).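

At this aromatic carbon, this assay now shows a change that goes beyond the scatter, though only modestly: 3-methoxyphenyl in place of 4-fluorophenyl gives a 2.1-fold lower number from compound 2 to compound 3 (0.33 log units; beyond the scatter) on the shared core. Methoxy in place of nitro gives a 1.7-fold lower number from compound 1 to compound 3 (0.23 log units; within the scatter) and stays within the scatter, so compound 1 and compound 3 cannot be told apart. The position therefore tolerates all three substituted phenyl groups with little change, and only compound 2 and compound 3 separate. No measurement here explains this step.

The compounds shown leave open whether the methoxy group itself matters or its place on the phenyl ring does, which 4-methoxyphenyl would test. They also leave open whether an amine or a carboxylic acid on this ring would move the number further.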